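Amine nitrogen substituent and cytotoxicity in the shared core

This account rests on a few compounds, and the source may have more. Where it says the series, first, only, none or still open, it means among the compounds named here.

Compound 3 `N#CC1=C(NC(=S)Nc2ccc(Br)cc2)N(c2ccc(S(N)(=O)=O)cc2)C2=C(C(=O)CCC2)C1c1ccc(Cl)cc1Cl` stands highest of the three compounds measured in a functional assay on Ehrlich cells (Mus musculus) for cytotoxicity, read by trypan blue exclusion, with a stated time of 2 h, tested at 50 ug/mL; a higher number here means a stronger effect of the compound at the concentration tested, a lower number a weaker effect; compound 3 gives 90%. Compound 1 `N#CC1=C(N)N(c2ccc(S(N)(=O)=O)cc2)C2=C(C(=O)CCC2)C1c1ccc(Cl)cc1Cl` gives 65% in this assay, and compound 2 `CCCCNC(=S)NC1=C(C#N)C(c2ccc(Cl)cc2Cl)C2=C(CCCC2=O)N1c1ccc(S(N)(=O)=O)cc1` gives 35%. The step of a number 55 percentage points higher from compound 2 to compound 3 (beyond the scatter) is the largest one seen; the step of a number 25 percentage points higher from compound 1 to compound 3 (beyond the scatter) is modest, and the step of a number 30 percentage points lower from compound 1 to compound 2 (beyond the scatter) runs the other way.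

Compound 4 `N#CC1=C(NC(=O)CCC(=O)O)N(c2ccc(S(N)(=O)=O)cc2)C2=C(C(=O)CCC2)C1c1ccc(Cl)cc1Cl` has not yet been measured in this assay. It differs from compound 3 as follows: a group of 7 heavy atoms (4 carbon, 3 oxygen; no ring) in place of a group of 10 heavy atoms (7 carbon, 1 nitrogen, 1 sulfur, 1 bromine; one six-membered aromatic ring of carbon only), on an amine nitrogen. Both steps into compound 3 bear on this change, as each concerns the group on the same amine nitrogen. The group that enters in compound 4 has no ring, like the butyl group of compound 2, which sits lowest; compound 1, with a hydrogen atom on this nitrogen, sits between. The expected step is therefore downward and beyond the scatter, about a number 45 percentage points lower from compound 3 to compound 4 (beyond the scatter). For compound 4 the estimate in this assay is 45%, with a range from 25% to 65%.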

Compound 4, a percentage reported as activity, at one concentration (the size of the read-out at that concentration, not a potency): 50%
Compound 4: the middle estimate sits 5 percentage points below what was measured; low and high end bracket the measured number.
By their numbers in this assay, from the lowest: compound 2; then compound 4; then compound 1; then compound 3.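

With (2-carboxyethyl)carbonyl on the amine nitrogen, this assay gives a number 40 percentage points lower from compound 3 to compound 4 (beyond the scatter) and so the high reading does not carry over to this group, which has no ring. Set against the free amine, the same group gives a number 15 percentage points lower from compound 1 to compound 4 (beyond the scatter) as its step, which makes it the second group after the butyl-bearing one of compound 2 to lower the number, while only the group of compound 3 raises it. The two groups without a ring are also apart, with a number 15 percentage points higher from compound 2 to compound 4 (beyond the scatter) as their step, so the absence of a ring alone does not fix the reading among these compounds.

Going by these compounds, whether the reading follows the carboxylic acid or the carbonyl on the nitrogen stays open, and a methyl ester or an acetyl group here would separate the two. Also open, on these data alone, is whether the high number of compound 3 goes with its ring or its bromine, which a plain phenyl in place of 4-bromophenyl would address. No measurement at hand accounts for any of these differences.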